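Fluorophenyl isomers on a sulfamide-linked piperazine acetamide series

The source may hold more compounds than are shown below. What is called first, only, known or untested is meant among the compounds shown, and "the series" means these compounds.

Measured so far:
compound 1 `CC1CCN(S(=O)(=O)N2CCN(CC(=O)Nc3cccc(F)c3)CC2)CC1` — 4600 nM
compound 2 `COc1ccc(Cl)cc1NC(=O)CN1CCN(S(=O)(=O)N2CCN(C(=O)N3CCCCC3)CC2)CC1` — > 10000 nM

Within the data shown here, in an assay on HEK293 cells for activation of potassium channel subfamily T member 1 (Homo sapiens), read by thallium flux (a higher number here means that more compound is needed for the effect, a lower number that less compound is needed), compound 1 gives 4600 nM, the only number obtained so far. Compound 2 reaches only a limit of the assay, > 10000 nM, and no number. Among the measured compounds shown here, no step between measured compounds is known here. Compound 3 `CC1CCN(S(=O)(=O)N2CCN(CC(=O)Nc3ccc(F)cc3)CC2)CC1` keeps the core of compound 1 and changes the amide substituent: 4-fluorophenyl in place of 3-fluorophenyl on an amide-type nitrogen. Cut one bond further out, this reads (3-fluorophenyl)amino to (4-fluorophenyl)amino. With only compound 1 as a reference and a change this small, the expected step from compound 1 to compound 3 is no change at the digits printed from compound 1 to compound 3 (within the scatter), none beyond the scatter. Compound 3 is therefore estimated at 4600 nM, with a range from 1500 nM to 14000 nM.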

Compound 3, half-maximal effective concentration: > 10000 nM
Compound 3: no number, only a limit; the forecaster's own chance of this, stated with the estimate: 25%; middle value at least 2.1-fold (0.33 log units) away from the limit.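

In this assay, 4-fluorophenyl in place of 3-fluorophenyl on an amide-type nitrogen gives an at least 2.1-fold higher number from compound 1 to compound 3 (0.33 log units; beyond the scatter). The two compounds have the same atoms, joined differently, so the amide substituent responds to the fluorine's placement alone. Compound 3 gives only a limit of the assay, > 10000 nM, so the step has no exact size: the limit of > 10000 nM in this assay, at which 2 of the 3 values shown sit.

Still open, from the compounds shown here alone, is whether a plain phenyl on the amide nitrogen keeps a measurable number. Also open, going by these compounds, is whether a nitrile in place of the fluorine of 3-fluorophenyl does so.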